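The compounds below may be only part of what the source reports. "The series", "measured", "known", "first", "only" and "open" are said of these compounds alone.

Measured so far in a functional assay on SK-OV-3 cells (Homo sapiens) for cytotoxicity, read by MTT assay, with a stated time of 48 h; a lower number here means a stronger inhibitor, a higher number a weaker inhibitor: compound 1 `O=C(/C=C/c1ccc2c(c1)B(O)OC2)c1ccc(-c2ccccc2)cc1` gives 4900 nM; compound 2 `O=C(/C=C/c1ccc2c(c1)B(O)OC2)c1ccc(Br)cc1` gives 4500 nM; compound 3 `CSc1ccc(C(=O)/C=C/c2ccc3c(c2)B(O)OC3)cc1` gives 4100 nM.

Among these three numbers compound 2 holds the second highest, though its step to compound 1, a 1.1-fold lower number from compound 1 to compound 2 (0.04 log units; within the scatter), and its step to compound 3, a 1.1-fold lower number from compound 2 to compound 3 (0.04 log units; within the scatter), both lie within the scatter. Compound 4 `O=C(/C=C/c1ccc2c(c1)B(O)OC2)c1ccccc1O` has not been measured. It differs from compound 2 by 2-hydroxyphenyl in place of 4-bromophenyl on a carbonyl carbon. Among the measured compounds shown here, no measured step makes this exchange; the nearest comparisons, a 1.1-fold lower number from compound 1 to compound 2 (0.04 log units; within the scatter), a 1.2-fold lower number from compound 1 to compound 3 (0.08 log units; within the scatter) and a 1.1-fold lower number from compound 2 to compound 3 (0.04 log units; within the scatter), each swapped a group on the ring attached to the carbonyl carbon and none moved beyond the scatter. Compound 4 is therefore expected to show no step beyond the scatter, no change at the digits printed from compound 2 to compound 4 (within the scatter), in this assay. Compound 4 is estimated at 4500 nM, between 1500 nM and 14000 nM.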

Compound 4, half-maximal inhibitory concentration: 48800 nM
Compound 4: the middle estimate sits 11-fold (1.04 log units) below what was measured, and the stated range ends below it.
By their numbers in this assay, from the lowest: compounds 3, 2 and 1 (each within the scatter of the next); then compound 4.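

In this assay the exchange on the carbonyl carbon gave an 11-fold higher number from compound 2 to compound 4 (1.04 log units; beyond the scatter) whereas the swaps among compound 1, compound 2 and compound 3 all stayed within the scatter, which shows that the number at this position can move well beyond it. The step came from replacing 4-bromophenyl with 2-hydroxyphenyl, a change that removes the bromine and also alters the ring's substitution. Nothing available explains the rise.

The compounds shown do not separate the loss of bromine from the gain of hydroxy. From the compounds shown here alone, whether a methoxy group or an amine in place of that hydroxy would give a similar number stays open.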